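The compounds below may be only part of what the source reports. "The series", "measured", "known", "first", "only" and "open" are said of these compounds alone.

Measured compounds:
compound 1 `Nc1sc2c(c1C(=O)NCc1cccc(Cl)c1)CCN(Cc1ccccc1)C2`: > 20000 nM
compound 2 `CN1CCc2c(sc(N)c2C(=O)NCc2ccccc2)C1`: 12000 nM

Among the measured compounds shown here, in an in vitro assay on CHOk1 cells with adenosine receptor A1 (Homo sapiens) as the target (a higher number here means that more compound is needed for the effect, a lower number that less compound is needed), compound 2 gives 12000 nM, the only number among the two values shown. The value of compound 1 in this assay is a limit of the assay, not a number (the limit of > 20000 nM in this assay, at which 1 of the 2 values shown sits). Compound 3 `CN1CCc2c(sc(N)c2C(=O)NCc2cccc(Cl)c2)C1` carries chloro in place of hydrogen on an aromatic carbon, chloro in place of hydrogen on an aromatic carbon. No step between measured compounds is shown, so the expected step is modest: the estimated change from compound 2 to compound 3 is no change at the digits printed from compound 2 to compound 3 (within the scatter), within the scatter. Compound 3 is therefore expected near 12000 nM, ranging from 4000 nM to 30000 nM.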

Compound 3, half-maximal effective concentration: 13200 nM
Beside the measured number, compound 3's estimate is 1.1-fold (0.04 log units) below it; measured number inside the range.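

In this assay the change from phenyl to 3-chlorophenyl gives a 1.1-fold higher number from compound 2 to compound 3 (0.04 log units; within the scatter), so at this place the chloro separates the two compounds by no more than the scatter. Hydrogen in place of phenyl on the saturated chain carbon bound to the ring amine nitrogen gives an at least 1.5-fold lower number from compound 1 to compound 3 (0.18 log units; that floor lies within the scatter). Compound 1 stands at a limit of the assay, so this step is only a floor: the limit of > 20000 nM in this assay, at which 1 of the 3 values shown sits.

The compounds shown leave open whether a methoxy or a carboxylic acid at this place would separate from hydrogen and chloro, and how a longer chain on that nitrogen would read.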